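This account rests on a few compounds, and the source may have more. Where it says the series, first, only, none or still open, it means among the compounds named here.

Measured so far:
compound 1, `CC(=O)O[C@@H]1OC(=O)[C@](C)(C(C)=O)[C@@H]1C`, with 4000 nM in a functional assay on B16 cells (Mus musculus) for cytotoxicity, read by MTT assay; on this read-out lower numbers stand for stronger inhibition and higher numbers for weaker inhibition
compound 2, `CC(=O)O[C@@H]1OC(=O)[C@@](C)(C(C)=O)[C@@H]1C`, with 14000 nM

Compound 2 gives the highest of the two numbers in this assay; its nearest neighbour is compound 1, reached by a 3.5-fold higher number from compound 1 to compound 2 (0.54 log units; beyond the scatter). The two share all atoms and bonds and differ only in how one stereocentre at a saturated ring carbon is drawn, so the size of that step rests on (the fact that compounds 1 and 2 differ only in the configuration as drawn).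

Compound 3, `CC(=O)O[C@@H]1OC(=O)[C@@](C)(C(=O)c2ccccc2)[C@@H]1C`, has not yet been measured. Starting from compound 2, the change is phenyl in place of methyl on a carbonyl carbon: a phenyl in place of methyl on a carbonyl carbon, the carbonyl carbon carrying a saturated ring carbon as its other neighbour. Within the data shown here, no measured pair shows this exchange; the only step in hand is the one between compound 1 and compound 2, which concerns configuration alone and so says nothing about a phenyl for methyl swap. With no guide, the expected step is a 1.4-fold lower number from compound 2 to compound 3 (0.15 log units; within the scatter), that is, none beyond the scatter in either direction, with a wide range to allow for the unknown. Compound 3 is therefore estimated at 10000 nM in this assay, between 2500 nM and 40000 nM.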

Compound 3, half-maximal inhibitory concentration: 7000 nM
Compound 3: the middle estimate sits 1.4-fold (0.15 log units) above what was measured; the range from low to high includes it.
By their numbers in this assay, from the lowest: compounds 1, 3 and 2 (each within the scatter of the next, the first and the last beyond it).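

In this assay, the exchange of methyl for phenyl on a carbonyl carbon comes out as a 2.0-fold lower number from compound 2 to compound 3 (0.30 log units; within the scatter), so at this place the read-out does not separate the two groups, even though phenyl brings one six-membered aromatic ring of carbon only where methyl stood. This is the first step among these compounds that changes a group rather than a drawn configuration, and it shows that the carbonyl carbon can carry a far larger substituent than methyl with no change beyond the scatter. Nothing available explains the size of this step, as the one fact in hand concerns only the configuration of compound 1 and compound 2.

Phenyl appears here only with the configuration drawn in compound 2, so it remains open whether the same exchange would read the same way with the configuration of compound 1. Also open, going by these compounds, is how an amine, a carboxylic acid or a longer chain on the carbonyl carbon would read in this assay, and whether any such group would move the number beyond the scatter from compound 2.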